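Lengthening the hydroxy side chain of compound 2

The source may report more compounds than this note shows. Statements on the series, on what has been measured and on what is new or still open speak of the compounds shown alone.

In a functional assay on HeLa cells (Homo sapiens) for cytotoxicity, read by MTT assay (on this read-out lower numbers stand for stronger inhibition and higher numbers for weaker inhibition), compound 1 (`CC(=O)OCCC(=O)O[C@H](CC=C(C)C)C1=CC(=O)c2c(O)ccc(O)c2C1=O`) gives 17300 nM and compound 2 (`CC[C@](C)(O)CC(=O)O[C@H](CC=C(C)C)C1=CC(=O)c2c(O)ccc(O)c2C1=O`) gives 30200 nM so these two sit within the scatter of each other. Compound 3 (`CCCCCCC(C)(O)CC(=O)O[C@H](CC=C(C)C)C1=CC(=O)c2c(O)ccc(O)c2C1=O`) carries 1-hydroxy-1-methylheptyl in place of 1-hydroxy-1-methylpropyl on a saturated chain carbon bound to a carbonyl carbon. Among the measured compounds shown here, the only measured step (a 1.7-fold higher number from compound 1 to compound 2 (0.24 log units; within the scatter)) lies within the scatter and swaps a different group. On this thin evidence, no step beyond the scatter is expected in this assay here. For compound 3 the estimated value is 25000 nM with a range from 10000 nM to 60000 nM around it. This expected change (a 1.2-fold lower number from compound 2 to compound 3 (0.08 log units; within the scatter)) stays within the scatter.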

Compound 3, half-maximal inhibitory concentration: > 100000 nM
Compound 3: a limit, no number (the forecaster's own chance of this, stated with the estimate: 10%); middle value at least 4.0-fold (0.60 log units) from the limit.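

In this assay compound 3 reads > 100000 nM, which is a limit and not a number. Lengthening 1-hydroxy-1-methylpropyl to 1-hydroxy-1-methylheptyl gives an at least 3.3-fold higher number from compound 2 to compound 3 (0.51 log units; beyond the scatter), and replacing acetoxymethyl with 1-hydroxy-1-methylheptyl gives an at least 5.7-fold higher number from compound 1 to compound 3 (0.76 log units; beyond the scatter), the first steps at this position beyond the scatter. The position therefore responds to this longer chain, but both steps are only lower bounds: the limit of > 100000 nM in this assay, at which 1 of the 3 values shown sits.

The compounds shown leave open how the number moves with the shorter 1-hydroxy-1-methylpentyl group in this place. They also leave open whether an amine or a carboxylic acid at the end of the long chain would bring the number back down.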